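This account rests on a few compounds, and the source may have more. Where it says the series, first, only, none or still open, it means among the compounds named here.

In a functional assay on HepG2 cells (Homo sapiens) for inhibition, read by MTT assay, with a stated time of 3 days (a lower number here means a stronger inhibitor, a higher number a weaker inhibitor), compound 3 `COc1cc(-c2nc3ccccc3s2)ccc1OCC(=O)NNC(=O)CN(C(C)=O)[C@@H](CS)C(=O)O` gives 3420 nM. That value is within the scatter of the other two measured compounds: compound 1 `CC[C@H](C)[C@H](NCC(=O)NNC(=O)COc1ccc(-c2nc3ccccc3s2)cc1OC)C(=O)O` gives 3540 nM and compound 2 `COc1cc(-c2nc3ccccc3s2)ccc1OCC(=O)NNC(=O)CN[C@@H](CS)C(=O)O` gives 3120 nM. Compound 4 `COc1cc(-c2nc3ccccc3s2)ccc1OCC(=O)NNC(=O)CN[C@@H](CCSC)C(=O)O` keeps the shared core but differs from compound 3 in its side chain: (1-carboxy-3-(methylsulfanyl)propyl)amino in place of acetyl(1-carboxy-2-sulfanylethyl)amino on a saturated chain carbon bound to a carbonyl carbon. Among the measured compounds shown here, three measured steps bear on this change. Replacing the sec-butyl group gives a 1.1-fold lower number from compound 1 to compound 2 (0.05 log units; within the scatter), replacing the whole amino group gives a 1.0-fold lower number from compound 1 to compound 3 (0.01 log units; within the scatter), and adding the acetyl gives a 1.1-fold higher number from compound 2 to compound 3 (0.04 log units; within the scatter). For the measured compounds named here, all three lie within the scatter, although no measured compound carries the methylsulfanyl chain. The expected step is small, a 1.0-fold lower number from compound 3 to compound 4 (0.02 log units; within the scatter), and none beyond the scatter is expected. For compound 4 the estimated value is 3300 nM, with an expected range of 1700 nM to 6500 nM.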

Compound 4, half-maximal inhibitory concentration: 3780 nM
Compound 4: the middle estimate sits 1.1-fold (0.06 log units) below what was measured; the range from low to high includes it.
By their numbers in this assay, from the lowest: compounds 2, 3, 1 and 4 (each within the scatter of the next).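

In this assay, among the compounds shown here, the methylsulfanyl chain, absent from the earlier compounds, leaves the number within the scatter of all three: 2-(methylsulfanyl)ethyl in place of sec-butyl (a 1.1-fold higher number from compound 1 to compound 4 (0.03 log units; within the scatter)), (methylsulfanyl)methyl in place of sulfanyl (a 1.2-fold higher number from compound 2 to compound 4 (0.08 log units; within the scatter)) and the exchange of the whole acetylated amino group (a 1.1-fold higher number from compound 3 to compound 4 (0.04 log units; within the scatter)). Across these four compounds, then, no side chain tried at this position separates from the others. No available evidence explains this flat result. On these data alone, whether a phenyl ring or a primary amine on this chain would move the number beyond the scatter remains open.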